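A few compounds are considered here, and "the series" means these few. Any claim that something is new, unique, unknown or untested is made for them only; others in the source may bear on it.

Measured compounds:
- Compound 1, `CC(C)(C)c1ccc(C(=O)N2CCC3(CC2)C(=O)N(CC(=O)NCCO)CN3c2ccccc2)cc1`: 1000 nM in an assay on HEK293 cells for displacement of a labelled ligand from NPC1-like intracellular cholesterol transporter 1 (Homo sapiens); on this read-out lower numbers stand for stronger inhibition and higher numbers for weaker inhibition
- Compound 2, `CC1(C)CC(OC(=O)CN2CN(c3ccccc3)C3(CCN(C(=O)c4ccc(C5CCCCC5)cc4)CC3)C2=O)CC(C)(C)N1`: 600 nM in this assay

Two compounds carry numbers in this assay. Compound 1 has the higher of the two, though its gap to compound 2 is within the scatter of repeated measurements, so the two values cannot be told apart and neither compound can be called the stronger.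

Compound 3, `CC(C)(C)c1ccc(C(=O)N2CCC3(CC2)C(=O)N(CC(=O)NCCCCN)CN3c2ccccc2)cc1`, has not yet been measured in this assay. It differs from compound 1 in one place: 2-aminoethyl in place of hydroxy on a saturated chain carbon, two bonds along the chain from an amide-type nitrogen. Among the compounds with values here, no step between two measured compounds shows what such an exchange does here, so there is no measured precedent to lean on. Compound 3 is expected to land close to compound 1, with the step from a 1.3-fold lower number from compound 1 to compound 3 (0.10 log units; within the scatter) expected to stay within the scatter. Compound 3 is therefore estimated at 800 nM, within a range of 300 nM to 2500 nM.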

Compound 3, half-maximal inhibitory concentration: 14500 nM
Estimate against measurement, compound 3: 18-fold (1.26 log units) below; the measured number lies above the stated range.
By their numbers in this assay, from the lowest: compounds 2 and 1 (each within the scatter of the next); then compound 3.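

In this assay, putting 2-aminoethyl in place of hydroxy on a saturated chain carbon, two bonds along the chain from an amide-type nitrogen, produces a clear step: a 15-fold higher number from compound 1 to compound 3 (1.16 log units; beyond the scatter). This position is therefore not indifferent to what it carries, even though both groups count the same hydrogen-bond donors and acceptors and no net charge, so those counts alone do not track the change in the number. Nothing available here bears on why the number moves this far.

The exchange alters both the length of the chain and its end group, and the compounds shown do not separate the two. An amine on the shorter chain of compound 1, or a longer chain still ending in hydroxy, would tell which of them goes with the step.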